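Compound 2 to compound 4: exchange at the carbonyl

The compounds below may be only part of what the source reports. "The series", "measured", "known", "first", "only" and "open" are said of these compounds alone.

Values in a functional assay on NCI-H661 cells (Homo sapiens) for antiproliferative activity, read by MTT assay, with a stated time of 72 h; a higher number here means a weaker inhibitor, a lower number a stronger inhibitor:
- compound 1 `Nc1ccccc1NC(=O)CCCCCCc1nc(-c2ccc(Cl)cc2)no1`: 11200 nM
- compound 2 `Nc1ccccc1NC(=O)CCCCCCc1nc(-c2ccc([N+](=O)[O-])cc2)no1`: > 100000 nM (a limit)
- compound 3 `Nc1ccccc1NC(=O)CCCCCCc1nc(-c2cccc([N+](=O)[O-])c2)no1`: 7290 nM

Compound 2 is known only as > 100000 nM, which is a limit of the assay and not a number. This is the limit of > 100000 nM in this assay, at which 1 of the 3 values shown sits.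

Compound 4 `O=C(CCCCCCc1nc(-c2ccc([N+](=O)[O-])cc2)no1)C(F)(F)F` carries trifluoromethyl in place of (2-aminophenyl)amino on a carbonyl carbon. The counted difference is trifluoromethyl in place of (2-aminophenyl)amino on a carbonyl carbon.

For the measured compounds named here, no measured step touches this exchange, so the series offers no direct precedent. The steps that involve compound 2 change only the aromatic substituent: an at least 8.9-fold higher number from compound 1 to compound 2 (0.95 log units; beyond the scatter) and an at least 13-fold lower number from compound 2 to compound 3 (1.13 log units; beyond the scatter). Both lie beyond the scatter, whereas a 1.5-fold lower number from compound 1 to compound 3 (0.19 log units; within the scatter) stays within it. Compound 4 keeps the aromatic substituent of compound 2, and this favours a weak result in this assay. Starting from a limit, the change can only be read as no visible shift or as a move to a lower number. A modest move to a lower number is expected, with wide uncertainty, and a second limit remains possible.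

The expected step is an at least 3.3-fold lower number from compound 2 to compound 4 (0.52 log units; beyond the scatter).

For compound 4 the estimate is 30000 nM, with an expected range from 6000 nM to 100000 nM.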

Compound 4, half-maximal inhibitory concentration: 17500 nM
Estimate against measurement, compound 4: 1.7-fold (0.23 log units) above; the measured number falls inside the stated range.
By their numbers in this assay, from the lowest: compounds 3, 1 and 4 (each within the scatter of the next, the first and the last beyond it). At a limit, above all of these: compound 2.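

In this assay, for the compounds shown here, the exchange at the carbonyl gives an at least 5.7-fold lower number from compound 2 to compound 4 (0.75 log units; beyond the scatter), the first reading at this position, as the earlier steps changed only the aromatic substituent. With the 4-nitrophenyl substituent held constant, the (2-aminophenyl)amino group is thus not needed for a measurable value: trifluoromethyl in its place, with 4 heavy atoms against 8 and no ring, leaves compound 4 at 17500 nM. Compound 2 stands only as a limit, so this step has a bound and no exact size: the limit of > 100000 nM in this assay, at which 1 of the 4 values shown sits.

As far as these compounds go, the exchange is seen on one aromatic substituent only, and whether trifluoromethyl in place of (2-aminophenyl)amino reads the same way with the 3-nitrophenyl of compound 3 or the 4-chlorophenyl of compound 1 remains open. Also open, from the compounds shown here alone, is how other groups on the carbonyl carbon, such as a hydroxyamino group or a plain methyl, would read, and whether a shorter or longer saturated chain would shift the value of compound 4.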